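Fluoro Added Ortho on the Benzoyl Ring

The source may hold more compounds than are shown below. What is called first, only, known or untested is meant among the compounds shown, and "the series" means these compounds.

Measured compounds:
compound 1 `O=C(Nc1cc(-c2ccccc2)nn1-c1ccccc1)c1ccc(F)cc1` — 50 nM
compound 2 `O=C(Nc1cc(-c2ccccc2)nn1-c1ccccc1)c1cccc(Cl)c1` — 200 nM
compound 3 `O=C(Nc1cc(-c2ccccc2)nn1-c1ccccc1)c1ccccc1` — 300 nM

All three share one core and differ only in the group on the carbonyl carbon. In an assay on isolated protein with metabotropic glutamate receptor 5 (Rattus norvegicus) as the target (a higher number here means that more compound is needed for the effect, a lower number that less compound is needed), compound 3 gives the highest number of the three; its step to compound 2 is within the scatter, while a 6.0-fold higher number from compound 1 to compound 3 (0.78 log units; beyond the scatter) lies well beyond it. The unmeasured compound 4 `O=C(Nc1cc(-c2ccccc2)nn1-c1ccccc1)c1ccccc1F` differs from compound 3 by fluoro in place of hydrogen on an aromatic carbon, placed ortho to a large group on the six-membered carbon ring.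

Among the measured compounds shown here, two steps bear on this. The fluoro on the same ring in compound 1 is linked to a 6.0-fold higher number from compound 1 to compound 3 (0.78 log units; beyond the scatter), a clear gain in potency. The chloro of compound 2 shows a 1.5-fold higher number from compound 2 to compound 3 (0.18 log units; within the scatter), which is within the scatter. Neither fluoro sits at the position now filled, so the expectation is cautious: a small gain at most.

Compound 4 is therefore expected to give 150 nM, with a likely range of 50 nM to 450 nM, which means an expected step of a 2.0-fold lower number from compound 3 to compound 4 (0.30 log units; within the scatter).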

Compound 4, half-maximal effective concentration: 100 nM
Compound 4: the middle estimate sits 1.5-fold (0.18 log units) above what was measured; the measured number falls inside the stated range.
By their numbers in this assay, from the lowest: compounds 1, 4, 2 and 3 (each within the scatter of the next, the first and the last beyond it).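

In this assay, fluoro on an aromatic carbon ortho to a large group gives a 3.0-fold lower number from compound 3 to compound 4 (0.48 log units; beyond the scatter), a step beyond the scatter, so a gain from fluoro on this ring is not tied to the position it holds in compound 1. The 2-fluorophenyl compound cannot be ranked against the other two substituted compounds, since a 2.0-fold lower number from compound 2 to compound 4 (0.30 log units; within the scatter) and a 2.0-fold higher number from compound 1 to compound 4 (0.30 log units; within the scatter) both lie within the scatter. Nothing measured here explains why this change lowers the number.

On these data alone, whether this position would also accept chloro, methoxy or an amine remains open. So does whether 2,4-difluorophenyl, carrying fluoro at both positions, would lower the number further than either single fluoro.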